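Carboxy in Place of Methyl on the Nitrogen-Bound Ring

The compounds below may be only part of what the source reports. "The series", "measured", "known", "first", "only" and "open" are said of these compounds alone.

In a functional assay on NCI-H292 cells (Homo sapiens) for antiproliferative activity (on this read-out higher numbers stand for weaker inhibition and lower numbers for stronger inhibition), compound 1 `O=C1N/C(=C\c2ccc(Br)cc2)C(=O)N1c1ccc(Cl)cc1` gives 46600 nM and compound 2 `Cc1ccc(N2C(=O)N/C(=C\c3ccc(O)cc3)C2=O)cc1` gives 27900 nM, two numbers that lie within the usual scatter of each other. For compound 3 `O=C1N/C(=C\c2ccc(O)cc2)C(=O)N1c1cccc(I)c1` this assay reports only a limit, > 200000 nM. Going by the values given here, the single measured step on the ring attached to the amide-type nitrogen runs an at least 7.1-fold higher number from compound 2 to compound 3 (0.85 log units; beyond the scatter), with compound 3 sitting at the limit of > 200000 nM in this assay, at which 1 of the 3 values shown sits. Compound 4 `O=C(O)c1ccc(N2C(=O)N/C(=C\c3ccc(O)cc3)C2=O)cc1` differs from compound 2 by carboxy in place of methyl on an aromatic carbon. That earlier step points toward weaker inhibition whenever this ring is altered, so a loss of similar size is expected here. Compound 4 is therefore estimated at 90000 nM, between 30000 nM and 250000 nM. This expected shift amounts to a 3.2-fold higher number from compound 2 to compound 4 (0.51 log units; beyond the scatter).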

Compound 4, half-maximal inhibitory concentration: > 200000 nM
Compound 4 ended at the assay's limit; the forecaster's own chance of this, stated with the estimate: 40%; at least 2.2-fold (0.34 log units) between middle value and limit.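

In this assay carboxy in place of methyl on an aromatic carbon, para to a large group, brings an at least 7.1-fold higher number from compound 2 to compound 4 (0.85 log units; beyond the scatter) and so shows that a second, different replacement on this ring also weakens inhibition relative to compound 2. The value of compound 4 is a limit, so the size of this loss has only a lower bound: the limit of > 200000 nM in this assay, at which 2 of the 4 values shown sit.

From the compounds shown here alone, whether a methyl ester, an amine or a longer chain at this place would keep the level of compound 2 stays open. Going by these compounds, how far compound 4 lies beyond the limit also stays open.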